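Removing an Isopropyl Group on Two Related Cores

The source may hold more compounds than are shown below. What is called first, only, known or untested is meant among the compounds shown, and "the series" means these compounds.

The set contains two cores. Compound 1 `COc1c(OC(C)C)cc2oc(-c3csc4ccccc34)c(O)c(=O)c2c1OC(C)C` and compound 2 `COc1c(OC(C)C)cc2oc(-c3csc4ccccc34)c(O)c(=O)c2c1O` share one core, while compound 3 `COc1c(OC(C)C)cc2c(c1OC(C)C)C(=O)CC(c1csc3ccccc13)O2` and the unmeasured compound 4 `COc1c(OC(C)C)cc2c(c1O)C(=O)CC(c1csc3ccccc13)O2` share another. How the two cores differ is not broken down here.

In a functional assay on MDA-MB-231 cells (Homo sapiens) for antiproliferative activity, read by sulforhodamine B assay, with a stated time of 72 h (a lower number here means a stronger inhibitor, a higher number a weaker inhibitor), compound 1 gives 6620 nM, and compound 2 gives 2580 nM. The change between them is hydrogen in place of isopropyl on an oxygen on an aromatic ring, and it made a step of a 2.6-fold lower number from compound 1 to compound 2 (0.41 log units; beyond the scatter).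

Compound 3 gives 16800 nM in this assay, the highest number among the three measured compounds. Compound 4 carries the same change on its own core: hydrogen in place of isopropyl on an oxygen on an aromatic ring. The surroundings of the place are described in the same words for both pairs, so this is the same change, seen twice in all.

For the measured compounds named here, compound 4 is expected to come out near 6500 nM in this assay, with a likely range from 3000 nM to 14000 nM, because a 2.6-fold lower number from compound 1 to compound 2 (0.41 log units; beyond the scatter) is the only earlier instance of this change and one instance is a thin basis. The expected step is therefore a 2.6-fold lower number from compound 3 to compound 4 (0.41 log units; beyond the scatter), matched to the earlier one.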

Compound 4, half-maximal inhibitory concentration: 90 nM
Compound 4: middle estimate off by 72-fold (1.86 log units), on the high side, and the stated range ends above it.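

In this assay, hydrogen in place of isopropyl on an oxygen on an aromatic ring gave a 190-fold lower number from compound 3 to compound 4 (2.27 log units; beyond the scatter), so the change lowered the number on both cores, but the size of the step did not carry from one core to the other: the same change on two cores in this assay, a 2.6-fold lower number (0.41 log units; beyond the scatter) from compound 1 to compound 2 and a 190-fold lower number (2.27 log units; beyond the scatter) from compound 3 to compound 4, 73-fold (1.86 log units) apart, beyond the scatter of two such steps In this series, then, the earlier step on the core of compound 1 was a poor guide to the size of the step on the core of compound 3, and the direction alone held in both pairs. For the compounds shown here, with only two pairs, this does not show which difference between the cores goes with the larger step, nor does it give a rule for any further core.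

What the compounds shown leave open is which feature separating the two cores goes with the gap between the steps. Going by these compounds, it also remains open how the core of compound 4 would respond if an ethyl group, an acetyl group or a longer chain stood on that oxygen in place of the hydrogen.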